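Series notes: aryl versus cyclohexylmethyl on the amine nitrogen

The source may hold more compounds than are shown below. What is called first, only, known or untested is meant among the compounds shown, and "the series" means these compounds.

Measured compounds:
compound 1 `OC[C@H]1OC(n2cnc3c(Nc4ccc(Cl)cc4)ncnc32)[C@H](O)[C@@H]1O`: 2.19 nM
compound 2 `OC[C@H]1OC(n2cnc3c(NCC4CCCCC4)ncnc32)[C@H](O)[C@@H]1O`: 39.8 nM

In an assay on isolated protein for binding affinity to adenosine receptor A1 (Rattus norvegicus) (on this read-out higher numbers stand for weaker inhibition and lower numbers for stronger inhibition), compound 2 gives the highest of the two numbers; compound 1 is its nearest neighbour, and an 18-fold higher number from compound 1 to compound 2 (1.26 log units; beyond the scatter). Compound 3 `COc1ccccc1Nc1ncnc2c1ncn2C1O[C@H](CO)[C@@H](O)[C@H]1O` is not yet measured. Its change from compound 2 is 2-methoxyphenyl in place of cyclohexylmethyl on a nitrogen on an aromatic ring. For the measured compounds named here, the one step on record, from compound 1 to compound 2, exchanged an aryl group for cyclohexylmethyl and the number rose sharply; compound 3 reverses that direction with an aryl group again, though a different one. A return toward compound 1 is therefore expected, a 4.0-fold lower number from compound 2 to compound 3 (0.60 log units; beyond the scatter). The estimate for compound 3 is 10 nM, with a range of 3 nM to 40 nM.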

Compound 3, half-maximal inhibitory concentration: 85.1 nM
Beside the measured number, compound 3's estimate is 8.5-fold (0.93 log units) below it, and the stated range ends below it.
By their numbers in this assay, from the lowest: compound 1; then compound 2; then compound 3.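

In this assay an aryl group on this nitrogen does not by itself bring the number back down: 2-methoxyphenyl in place of cyclohexylmethyl gives a 2.1-fold higher number from compound 2 to compound 3 (0.33 log units; beyond the scatter) and 2-methoxyphenyl in place of 4-chlorophenyl gives a 39-fold higher number from compound 1 to compound 3 (1.59 log units; beyond the scatter) here. Compound 2, with no aryl group, thus falls between the two aryl compounds, so aryl versus cyclohexylmethyl alone does not set the order. Nothing on hand bears on the reason for this order.

Still open, as far as these compounds go, is how an unsubstituted phenyl or a benzyl group on this nitrogen would read. Also open, from the compounds shown here alone, is whether the methoxy and chloro groups themselves, or where each stands on the ring, carry the difference between compound 1 and compound 3.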